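The source may hold more compounds than are shown below. What is called first, only, known or untested is meant among the compounds shown, and "the series" means these compounds.

Three compounds of the series have been run in a functional assay on the whole organism (strain Wistar albino) for inhibition, with Rattus norvegicus as the target, read by paw edema, with a stated time of 2 h, at a dose of 100 mg/kg by the oral route; on this read-out lower numbers stand for less inhibition and higher numbers for more inhibition at the one dose given (going by the name of the read-out). Compound 1 `Cc1ccc2c(Cc3nn4cc(-c5ccc(Cl)cc5)nc4s3)coc2c1` gives 42.1%, compound 2 `Cc1ccc2c(Cc3nn4c(C=O)c(-c5ccc(Cl)cc5)nc4s3)coc2c1` gives 24.3%, and compound 3 `Cc1ccc2c(Cc3nn4c(C=O)c(-c5ccc(Br)cc5)nc4s3)coc2c1` gives 11.2%. Compound 2 stands second highest of the three, set apart from both neighbours beyond the scatter: a number 17.8 percentage points lower from compound 1 to compound 2 (beyond the scatter) and a number 13.1 percentage points lower from compound 2 to compound 3 (beyond the scatter). Compound 4 `Cc1ccc2c(Cc3nn4c(CO)c(-c5ccc(Cl)cc5)nc4s3)coc2c1` is not yet measured; it differs from compound 2 by hydroxymethyl in place of formyl on an aromatic carbon. Among the measured compounds shown here, no measured step swaps formyl for hydroxymethyl. For the measured compounds named here, the one step at that carbon, a number 17.8 percentage points lower from compound 1 to compound 2 (beyond the scatter), put formyl in place of hydrogen; the added hydrogen-bond donor has no precedent here. The step of a number 5.7 percentage points higher from compound 2 to compound 4 (within the scatter) is therefore expected to stay within the scatter, leaning upward. Compound 4 is estimated at 30%, range 15% to 45%.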

Compound 4, a percentage reported as inhibition, in the whole organism at one dose (the size of the read-out at that dose, not a potency): 28.9%
The estimate for compound 4 lay 1.1 percentage points above the measured number; measured number inside the range.
By their numbers in this assay, from the lowest: compound 3; then compounds 2 and 4 (each within the scatter of the next); then compound 1.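

At this carbon, next to the ring nitrogen, the change from formyl to hydroxymethyl adds a hydrogen-bond donor, yet in this assay it gives only (a number 4.6 percentage points higher from compound 2 to compound 4 (within the scatter)), so the two groups are not told apart. Hydroxymethyl still stands apart from hydrogen, with (a number 13.2 percentage points lower from compound 1 to compound 4 (beyond the scatter)), so the lower number on substitution here is not confined to formyl. Nothing measured on these compounds bears on why.

On these data alone, whether an amine or a carboxylic acid at this carbon would also fall short of hydrogen remains open. So does whether bromo in place of chloro lowers the number with hydroxymethyl present, as it does with formyl.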